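A Piperidine Amide Replaces a Weak Anilide Tail

A few compounds are considered here, and "the series" means these few. Any claim that something is new, unique, unknown or untested is made for them only; others in the source may bear on it.

Of the compounds shown here, three sharing one core have been tested in an assay on isolated protein for inhibition of glutathione S-transferase P (Homo sapiens), with a stated time of 10 min; a lower number here means a stronger inhibitor, a higher number a weaker inhibitor. Compound 1 `O=C(O)CCC(=O)OCCCCCCSc1ccc([N+](=O)[O-])c2nonc12` carries a free carboxylic acid and gives 530 nM. Compound 2 `COc1ccc(NC(=O)CCC(=O)OCCCCCCSc2ccc([N+](=O)[O-])c3nonc23)cc1`, its (4-methoxyphenyl)amide, gives 420 nM, and the move a 1.3-fold lower number from compound 1 to compound 2 (0.10 log units; within the scatter) is too small to read as a real change. Compound 3 `O=C(CCC(=O)OCCCCCCSc1ccc([N+](=O)[O-])c2nonc12)Nc1ccc(F)c(Cl)c1`, the (3-chloro-4-fluorophenyl)amide, gives 9850 nM and is the weakest inhibitor of the three: a 19-fold higher number from compound 1 to compound 3 (1.27 log units; beyond the scatter) and a 23-fold higher number from compound 2 to compound 3 (1.37 log units; beyond the scatter).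

Compound 4 `O=C(CCC(=O)N1CCCCC1)OCCCCCCSc1ccc([N+](=O)[O-])c2nonc12` differs from compound 3 by one change: piperidin-1-yl in place of (3-chloro-4-fluorophenyl)amino on a carbonyl carbon. Within the data shown here, no measured pair shows this exact exchange. What bears on it is that the acid and the methoxyanilide sit close together while the chlorofluoroanilide alone stands far off, so the two large steps into compound 3 mark how much room there is to recover. Among the measured compounds shown here, the group that leaves is the one present in compound 3 at 9850 nM, so a move back toward the numbers of compound 1 and compound 2 is expected, though without a direct precedent its size is uncertain. The expected step is a 6.6-fold lower number from compound 3 to compound 4 (0.82 log units; beyond the scatter). Compound 4 is estimated at 1500 nM, with a range from 400 nM to 6000 nM.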

Compound 4, half-maximal inhibitory concentration: 500 nM
Compound 4: middle estimate off by 3.0-fold (0.48 log units), on the high side, and the stated range covers the measured number.
By their numbers in this assay, from the lowest: compounds 2, 4 and 1 (each within the scatter of the next); then compound 3.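

In this assay, the exchange gives a 20-fold lower number from compound 3 to compound 4 (1.29 log units; beyond the scatter), so the loss seen in compound 3 does not extend to every amide at this carbonyl carbon. Compound 4 has no amide hydrogen and no aromatic ring in this group, yet a 1.2-fold higher number from compound 2 to compound 4 (0.08 log units; within the scatter) and a 1.1-fold lower number from compound 1 to compound 4 (0.03 log units; within the scatter) both stay within the scatter, so neither feature is needed to hold this level of inhibition. Hydroxy, (4-methoxyphenyl)amino and piperidin-1-yl therefore read alike here despite their different shapes, compound 3 alone stands apart, and no data are available to explain either the shared level or the exception.

As far as these compounds go, it remains open which part of the (3-chloro-4-fluorophenyl)amino group goes with the loss, a question that anilides carrying only the chlorine or only the fluorine could settle. From the compounds shown here alone, it is equally open whether a morpholine amide, a dimethylamide or a piperazine amide would stay at this same level or move clearly away from it in either direction.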